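This account rests on a few compounds, and the source may have more. Where it says the series, first, only, none or still open, it means among the compounds named here.

Measured compounds, with the numbers obtained in an assay on isolated protein for inhibition of ATP-dependent RNA helicase DDX3X (Homo sapiens), read by FRET, with stated times of 30 s and 40 min; on this read-out higher numbers stand for weaker inhibition and lower numbers for stronger inhibition:

Compound 1, `COCCc1cn(-c2ccc(NC(=O)Nc3ccccc3C)cc2)nn1`, gives 1000 nM in this assay.
Compound 2, `CCOC(=O)CCc1cn(-c2ccc(NC(=O)Nc3ccccc3C(F)(F)F)cc2)nn1`, gives 2020 nM in this assay.
Compound 3, `CCCCc1cn(-c2ccc(NC(=O)Nc3cc(OCOC)ccc3C)cc2)nn1`, gives 820 nM in this assay.

Compound 3 carries the lowest number of the three. Its gap to compound 1 lies within the scatter, so the two cannot be ordered; its gap to compound 2 lies beyond the scatter, and there compound 3 stands as the stronger inhibitor of the pair. Within the data shown here, the three compounds differ in more than one place at once, so no single step between measured compounds can be read off.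

Compound 4 is `CCCCc1cn(-c2ccc(NC(=O)Nc3cc(O[C@H]4O[C@@H](CO)[C@H](O)[C@@H]4O)ccc3C)cc2)nn1`. It follows from compound 3 by 3,4-dihydroxy-5-(hydroxymethyl)oxolan-2-yl in place of methoxymethyl on an oxygen on an aromatic ring. The entering group is far larger than the leaving one and brings a five-membered non-aromatic ring and several hydrogen-bond donors and acceptors where none stood before. Among the measured compounds shown here, no measured pair shows what such an exchange does in this assay, so the direction is open. With nothing to anchor it, a step of moderate size is expected, more likely toward a higher number than a lower one, though a result within the scatter of compound 3 cannot be excluded. The expected step from compound 3 to compound 4 is a 1.8-fold higher number from compound 3 to compound 4 (0.26 log units; within the scatter). Compound 4 is accordingly estimated at 1500 nM, within a range from 500 nM to 5000 nM.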

Compound 4, half-maximal inhibitory concentration: "not active" (no number reported)
No number was reported for compound 4; no gap can be computed for the estimate.
By their numbers in this assay, from the lowest: compounds 3 and 1 (each within the scatter of the next); then compound 2.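

In this assay, among these compounds, compound 4 is reported as not active, without a number, and no step from compound 3 to compound 4 can be read. Nothing measured here bears on this result. The compounds shown leave open how any single exchange on the shared core, on the oxygen or elsewhere, shifts the number.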